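Working notes: aryl exchange in a limit-bound series

This account rests on a few compounds, and the source may have more. Where it says the series, first, only, none or still open, it means among the compounds named here.

Compound 1 `Cc1ccc(C)c(-n2nncc2CN2C(=O)C3(C(C#N)=C(N)Oc4c3c3nc5ccccc5nc3c3ccccc43)c3ccccc32)c1` gives > 50000 nM in a functional assay on A549 cells (Homo sapiens) for antiproliferative activity, read by MTT assay, with a stated time of 48 h (on this read-out lower numbers stand for stronger inhibition and higher numbers for weaker inhibition), which is a limit of the assay and not a number. Compound 2 `N#CC1=C(N)Oc2c(N)cc3nc4ccccc4nc3c2C12C(=O)N(Cc1cnnn1-c1ccc(Cl)cc1)c1ccccc12` likewise gives only a limit in this assay, > 50000 nM. Both values shown sit at that limit (the limit of > 50000 nM in this assay, at which 2 of the 2 values shown sit), so compound 2 stands together with compound 1, with no number to separate them. Compound 3 `Cc1ccc(-n2nncc2CN2C(=O)C3(C(C#N)=C(N)Oc4c(N)cc5nc6ccccc6nc5c43)c3ccccc32)cc1Cl` differs from compound 2 by 3-chloro-4-methylphenyl in place of 4-chlorophenyl on an aromatic nitrogen. Going by the values given here, no measured step covers this change, and none beyond the scatter is expected in this assay. The expected step is a number no higher from compound 2 to compound 3 (the limit leaves the size open). Compound 3 is estimated at 50000 nM, ranging from 20000 nM to 100000 nM, most likely reported again only as a limit.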

Compound 3, half-maximal inhibitory concentration: 11800 nM
For compound 3 the middle estimate is 4.2-fold (0.63 log units) above the measured one; the measured number lies below the stated range.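

In this assay, the aryl group on the aromatic nitrogen proves able to move the read-out off the limit, with an at least 4.2-fold lower number from compound 2 to compound 3 (0.62 log units; beyond the scatter). Compound 3 is the first compound shown with a measured number rather than a limit. The true size of this step stays open because the value for compound 2 is only a limit: the limit of > 50000 nM in this assay, at which 2 of the 3 values shown sit.

Which part of the exchange carries the step remains open, as 3-chlorophenyl and 4-methylphenyl do not appear at this position among the compounds shown. Also open, from the compounds shown here alone, is how an aryl ring bearing an amine or a carboxylic acid would read here.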